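The compounds below may be only part of what the source reports. "The series", "measured", "known", "first", "only" and "open" are said of these compounds alone.

Compound 1, `Cc1cc(C(=O)O)nn1Cc1cc(Br)ccc1OCc1ccccc1`, is the reference point of this small set. In a functional assay on CHO-K1 cells for antagonist activity at prostaglandin E2 receptor EP1 subtype (Homo sapiens), read by FLIPR (a lower number here means a stronger inhibitor, a higher number a weaker inhibitor), compound 1 gives 15.1 nM, the lowest number among the three measured compounds. Its nearest neighbour is compound 2, `O=C(O)c1ccn(Cc2cc(Br)ccc2OCc2ccccc2)n1`, which in this assay gives 55 nM; the step is a 3.6-fold higher number from compound 1 to compound 2 (0.56 log units; beyond the scatter), brought about by hydrogen in place of methyl on an aromatic carbon of the shared core. Furthest away is compound 3, `CCCCc1cc(C(=O)O)nn1Cc1cc(Br)ccc1OCc1ccccc1`, which in this assay gives 977 nM, a step of a 65-fold higher number from compound 1 to compound 3 (1.81 log units; beyond the scatter) from compound 1 and of an 18-fold higher number from compound 2 to compound 3 (1.25 log units; beyond the scatter) from compound 2.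

Compound 4, `Cc1cccc(COc2ccc(Br)cc2Cn2nc(C(=O)O)cc2C)c1`, differs from compound 1 by methyl in place of hydrogen on an aromatic carbon, a change on the six-membered aromatic ring of carbon only, meta to a large group. Among the measured compounds shown here, none of the measured steps touches this ring: the step from compound 1 to compound 2 and the two steps involving compound 3 all concern the core or the saturated chain carbon bound to it. The measured data therefore give no direct guide, and no step beyond the scatter is expected in this assay for compound 4; the estimate is 20 nM, with a range from 6 nM to 65 nM, a step of a 1.3-fold higher number from compound 1 to compound 4 (0.12 log units; within the scatter) expected from compound 1.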

Compound 4, inhibition constant: 525 nM
Compound 4: the middle estimate sits 26-fold (1.42 log units) below what was measured, outside the stated range (above it).
By their numbers in this assay, from the lowest: compound 1; then compound 2; then compounds 4 and 3 (each within the scatter of the next).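

Placing methyl on an aromatic carbon of the six-membered aromatic ring of carbon only, meta to a large group, turns the benzyl of compound 1 into the 3-methylbenzyl of compound 4 and gives a 35-fold higher number from compound 1 to compound 4 (1.54 log units; beyond the scatter) in this assay. This ring had not been touched by any earlier step, and the result shows that it is not a part of the molecule that tolerates any change: a single added carbon is enough for a large step. Until now the only large steps from compound 1 had come from changes on the core side, such as a 65-fold higher number from compound 1 to compound 3 (1.81 log units; beyond the scatter), and the data shown contain nothing that explains the new loss at the benzyl end.

The compounds shown leave open whether the step belongs to methyl itself or to any group at this place, as a fluorine, a chlorine, a hydroxyl or a methoxy group there could tell. They also leave open whether methyl elsewhere on this ring, or the same 3-methylbenzyl on the core of compound 2, would give a step of similar size.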